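The compounds below may be only part of what the source reports. "The series", "measured", "known", "first", "only" and "open" are said of these compounds alone.

Three compounds have been measured in a functional assay on the whole organism (strain Wistar) for inhibition, with Rattus norvegicus as the target, read by paw edema, with a stated time of 4 h, at a dose of 10 mg/kg by the intraperitoneal route; on this read-out lower numbers stand for less inhibition and higher numbers for more inhibition at the one dose given (going by the name of the read-out):

compound 1, `O=C(N/N=C/c1cccc(F)c1)c1cccnc1Nc1cccc(C(F)(F)F)c1`, gives 29.8%
compound 2, `O=C(N/N=C/c1cccc(Cl)c1)c1cccnc1Nc1cccc(C(F)(F)F)c1`, gives 40.4%
compound 3, `CN(C)c1ccc(/C=N/NC(=O)c2cccnc2Nc2cccc(C(F)(F)F)c2)cc1`, gives 28.2%

Compound 1 stands second highest of these three numbers. Its nearest neighbour is compound 3, reached by a number 1.6 percentage points lower from compound 1 to compound 3 (within the scatter), a step within the usual scatter. Its furthest is compound 2, reached by a number 10.6 percentage points higher from compound 1 to compound 2 (beyond the scatter), a step beyond the scatter but still modest.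

Compound 4 is `O=C(N/N=C/c1cccnc1)c1cccnc1Nc1cccc(C(F)(F)F)c1`. Set against compound 1, it shows (pyridin-3-yl in place of 3-fluorophenyl on a carbon with a double bond to nitrogen).

Two measured steps change the same ring at the same place. From compound 1 to compound 3 the ring swap gave a number 1.6 percentage points lower from compound 1 to compound 3 (within the scatter), so no real movement. From compound 2 to compound 3 the ring swap gave a number 12.2 percentage points lower from compound 2 to compound 3 (beyond the scatter), a modest fall. Changing this ring therefore shifts the read-out by at most a modest amount, and often by nothing beyond the scatter. For compound 4 no step beyond the scatter is expected: a number 0.2 percentage points higher from compound 1 to compound 4 (within the scatter). Compound 4 is thus estimated at 30%, with an expected range from 18% to 42%.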

Compound 4, a percentage reported as inhibition, in the whole organism at one dose (the size of the read-out at that dose, not a potency): 36%
Compound 4: the middle estimate sits 6 percentage points below what was measured, and the stated range covers the measured number.
By their numbers in this assay, from the lowest: compounds 3, 1, 4 and 2 (each within the scatter of the next, the first and the last beyond it).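

Compound 4 is the only one of the four with a nitrogen in the ring on the carbon with a double bond to nitrogen, and in this assay the change from 3-fluorophenyl to pyridin-3-yl gives a number 6.2 percentage points higher from compound 1 to compound 4 (within the scatter), so a ring of carbon only is not required for a read-out of this size. Set against the other two rings, pyridin-3-yl gives a number 7.8 percentage points higher from compound 3 to compound 4 (within the scatter) and a number 4.4 percentage points lower from compound 2 to compound 4 (within the scatter), which leaves compound 4 impossible to tell apart from any of the three, even though a number 12.2 percentage points lower from compound 2 to compound 3 (beyond the scatter) separates the other two. No measurement at hand offers a reason for these numbers.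

The compounds shown leave open whether the place of the ring nitrogen matters, as a pyridin-2-yl or pyridin-4-yl ring would test, and whether a saturated ring such as piperidine or a carboxylic acid on the ring would move the read-out beyond the scatter. Going by these compounds, every compound here also keeps the same trifluoromethyl-bearing part of the core, so the effect of changing that part remains unknown, and a single dose gives no measure of potency.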